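One Substituent Swapped on a Shared Core: Compound 4

A few compounds are considered here, and "the series" means these few. Any claim that something is new, unique, unknown or untested is made for them only; others in the source may bear on it.

Compound 1 `CC1(C)C=C(n2ccccc2=O)c2cc(C(=N)NO)ccc2O1` gives 5.51 in a functional assay (trachea) with Rattus norvegicus as the target; on this read-out higher numbers stand for higher potency (the scale is a negative logarithm) and lower numbers for lower potency.
Compound 2 `CC1(C)C=C(n2ccccc2=O)c2cc(OC(=O)Nc3ccccc3C(F)(F)F)ccc2O1` gives 5.19 in this assay.
Compound 3 `CC1(C)C=C(n2ccccc2=O)c2cc(OC(=O)Nc3ccc(C(F)(F)F)cc3)ccc2O1` gives 4.54 in this assay.

Compound 1 stands highest of the three numbers. Compound 2 is the nearest, its number lower by a margin beyond the usual scatter, and compound 3 is the furthest, lower by a margin also beyond the scatter. Going by the values given here, the only measured step between two compounds that differ in one place is a number 0.65 log units lower from compound 2 to compound 3 (beyond the scatter), a swap of 4-(trifluoromethyl)phenyl for 2-(trifluoromethyl)phenyl on an amide-type nitrogen.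

Compound 4 `CC1(C)C=C(n2ccccc2=O)c2cc(OS(=O)(=O)F)ccc2O1` differs from compound 1 by a group of 5 heavy atoms (3 oxygen, 1 fluorine, 1 sulfur; no ring) in place of a group of 4 heavy atoms (1 carbon, 2 nitrogen, 1 oxygen; no ring), on an aromatic carbon. The (fluorosulfonyl)oxy group enters where the group with three hydrogen-bond donors leaves, on an aromatic carbon of the six-membered carbon ring of the fused system.

Among the compounds with values here, no measured step bears directly on this change: the step from compound 2 to compound 3 alters a different part of the molecule and gives no guide to the size or direction here. The three measured numbers do show where compounds of this core have landed so far, and that span is the best anchor. Compound 4 is therefore expected to give about 5 in this assay, within 4.3 to 5.7. The expected step of a number 0.51 log units lower from compound 1 to compound 4 (beyond the scatter) is a modest fall, held inside a wide range.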

Compound 4, logarithm of the reciprocal of the active concentration, log(1/C): 7.22
Beside the measured number, compound 4's estimate is 2.22 log units below it, and the stated range ends below it.
By their numbers in this assay, from the lowest: compound 3; then compound 2; then compound 1; then compound 4.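

Swapping the whole group on this aromatic carbon, para to a fused ring, gives a number 1.71 log units higher from compound 1 to compound 4 (beyond the scatter) in this assay, so this one position can move the number by a large amount, and upward. Going by these compounds alone, the only earlier step, a number 0.65 log units lower from compound 2 to compound 3 (beyond the scatter), was a fall made further out, by moving the trifluoromethyl around a phenyl ring, and it said nothing about replacing the group attached to the aromatic carbon. The new step also shows that hydrogen-bond donors on this group are not needed for a high number, since the (fluorosulfonyl)oxy group has none, but nothing measured here explains why the number rises.

The compounds shown cannot separate the part played by the fluorine from that of the sulfur and its oxygens, and a methanesulfonyloxy group, with a methyl in place of the fluorine, would test this directly. As far as these compounds go, it also remains open whether simpler groups on the same carbon, such as an amine or a carboxylic acid, would fall nearer compound 1 or nearer compound 4.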